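The source may hold more compounds than are shown below. What is called first, only, known or untested is meant among the compounds shown, and "the series" means these compounds.

Series in a functional assay on U-937 cells (Homo sapiens) for cytotoxicity, read by MTT assay and WST assay, with a stated time of 72 h; a higher number here means a weaker inhibitor, a lower number a stronger inhibitor:
compound 1 `COc1cc2c(Nc3ccc4sc(C(=O)Nc5c(C)cccc5Cl)cc4c3)ncnc2cc1OCCCN1CCCCC1C` gives 3450 nM;
compound 2 `CCN(CC)CCCOc1cc2ncnc(Nc3ccc4sc(C(=O)Nc5c(C)cccc5Cl)cc4c3)c2cc1OC` gives 4010 nM;
compound 3 `Cc1nc(Nc2ccc3sc(C(=O)Nc4c(C)cccc4Cl)cc3c2)cc(N2CCC(C)CC2)n1` gives 20600 nM.

Compound 3 stands highest of the three numbers, its gap to compound 2 and to compound 1 each beyond the scatter. Compound 4 `CCN1CCN(c2cc(Nc3ccc4sc(C(=O)Nc5c(C)cccc5Cl)cc4c3)nc(C)n2)CC1` differs from compound 3 by 4-ethylpiperazin-1-yl in place of 4-methylpiperidin-1-yl on an aromatic carbon. Going by the values given here, the only measured step that exchanges one amine group for another, a 1.2-fold higher number from compound 1 to compound 2 (0.07 log units; within the scatter), stayed within the scatter, though there the group sat on a saturated chain rather than on the aromatic carbon. Among the compounds with values here, no measured step trades a piperidine ring for a piperazine ring, so the bearing of that step is loose. The expected step is therefore a 1.1-fold lower number from compound 3 to compound 4 (0.06 log units; within the scatter), not beyond the scatter. Compound 4 is estimated at 18000 nM, within 7000 nM to 45000 nM.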

Compound 4, half-maximal inhibitory concentration: 13100 nM
Compound 4: the middle estimate sits 1.4-fold (0.14 log units) above what was measured, and the stated range covers the measured number.
By their numbers in this assay, from the lowest: compounds 1 and 2 (each within the scatter of the next); then compounds 4 and 3 (each within the scatter of the next).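

In this assay, 4-ethylpiperazin-1-yl in place of 4-methylpiperidin-1-yl on an aromatic carbon gives a 1.6-fold lower number from compound 3 to compound 4 (0.20 log units; within the scatter) as a step within the scatter. This position therefore accepts a ring with 2 hetero atoms and a larger group without a step beyond the scatter, as the amine exchange on the saturated chain also stayed within it. Nothing measured here accounts for this step.

Open, going by these compounds, is how 4-methylpiperazin-1-yl would read, which would separate the added ring nitrogen from the ethyl group. Morpholine or a primary amine on this aromatic carbon also remains to be placed.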